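The source may report more compounds than this note shows. Statements on the series, on what has been measured and on what is new or still open speak of the compounds shown alone.

Four compounds share one core and differ only in the group attached to its chain nitrogen. Compound 1 `CC(C)(C)C/N=C(/NC#N)Nc1cccnc1` in a functional assay on the whole organism (blood, strain Wistar-Okamoto) with Rattus norvegicus as the target, with a stated time of 5 days (a higher number here means that more compound is needed for the effect, a lower number that less compound is needed), gives 2.5 mg/kg. Compound 2 `CCCCCCC/N=C(\NC#N)Nc1cccnc1` gives > 50 mg/kg, which is a limit of this assay rather than a number. Compound 3 `CCCCC(CC)C/N=C(\NC#N)Nc1cccnc1` gives > 50 mg/kg, again only a limit. Compound 2 therefore stands at the limit of > 50 mg/kg in this assay, at which 2 of the 3 values shown sit, without a number of its own. Compound 4 `CCOCC/N=C(\NC#N)Nc1cccnc1` has not yet been measured; it differs from compound 2 by ethoxy in place of pentyl on a saturated chain carbon, two bonds along the chain from a double-bonded nitrogen. Since compound 1 gives 2.5 mg/kg, the smaller group entering compound 4 is expected to need less compound, a step beyond the scatter in this assay. The expected step runs an at least 5.0-fold lower number from compound 2 to compound 4 (0.69 log units; beyond the scatter). Compound 4 is thus estimated at 10 mg/kg, between 3 mg/kg and 50 mg/kg.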

Compound 4, minimum effective dose: > 20 mg/kg
Compound 4 ended at the assay's limit (the forecaster's own chance of this, stated with the estimate: 35%); middle value at least 2.0-fold (0.30 log units) from the limit.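

Compound 2 and compound 4 each carry only a limit of the assay rather than a number, and the step between them cannot be read. The compounds shown leave open whether ethoxy in place of pentyl changes the dose needed at all.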